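Methylating a ring hydroxy in a chalcone set

The source may report more compounds than this note shows. Statements on the series, on what has been measured and on what is new or still open speak of the compounds shown alone.

Four compounds are compared in a functional assay on HeLa cells (Homo sapiens) for inhibition, read by MTT assay, with a stated time of 72 h; a lower number here means a stronger inhibitor, a higher number a weaker inhibitor. Compound 1 `COc1cc(/C=C/C(=O)c2c(O)cc(O)cc2OC)ccc1O` gives only a limit here, > 50000 nM, as stated in the limit of > 50000 nM in this assay, at which 1 of the 3 values shown sits. Compound 2 `COc1ccc(/C=C/C(=O)c2c(O)cc(O)cc2OC)cc1OC` gives 49500 nM in this assay, and the step of a number no higher from compound 1 to compound 2 (the limit leaves the size open) is the change (methyl in place of hydrogen on an oxygen on an aromatic ring). Compound 3 `COc1cc(OC)c(C(=O)/C=C/c2ccc(O)c(O)c2)c(OC)c1` gives 15800 nM in this assay, the lowest of the two numbers, with compound 2 the nearest and beyond the scatter; how the core of compound 3 differs from the core of compound 1 is not broken down here. Compound 4 `COc1cc(OC)c(C(=O)/C=C/c2ccc(O)c(OC)c2)c(OC)c1` carries the change (methyl in place of hydrogen on an oxygen on an aromatic ring), the same change as between compound 1 and compound 2, at a place described in the same words. Because a number no higher from compound 1 to compound 2 (the limit leaves the size open) leaves the size open, a step near neutral is expected for compound 4, namely a 1.4-fold higher number from compound 3 to compound 4 (0.14 log units; within the scatter). Compound 4 is therefore estimated at 22000 nM, between 8000 nM and 60000 nM.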

Compound 4, half-maximal inhibitory concentration: 44900 nM
Compound 4: the middle estimate sits 2.0-fold (0.31 log units) below what was measured, within the range that was stated.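

In this assay the change from hydroxy to methoxy gives a 2.8-fold higher number from compound 3 to compound 4 (0.45 log units; beyond the scatter) on the core of compound 3. The change does not carry over with one size between the two cores: the same change on two cores in this assay, a number no higher (the limit leaves the size open) from compound 1 to compound 2 and a 2.8-fold higher number (0.45 log units; beyond the scatter) from compound 3 to compound 4, at least 2.8-fold (0.45 log units) apart, beyond the scatter of two such steps
Compound 1 stands at > 50000 nM as a limit, so the size of the step on its core cannot be read, and only its direction is known: the limit of > 50000 nM in this assay, at which 1 of the 4 values shown sits.

Still open, from the compounds shown here alone, is how a longer ether chain or a carboxylic acid on that oxygen would read in this assay on either core. Going by these compounds, with one pair per core, it also remains open why the two cores answer differently to the methyl and whether the gap holds at other ring hydroxy groups.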